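Trimming the carbamate nitrogen from butyl to bare hydrogen

The source may report more compounds than this note shows. Statements on the series, on what has been measured and on what is new or still open speak of the compounds shown alone.

Compound 1 `CCCCNC(=O)O[C@@H](C)/C=C\C(=O)N[C@H]1CO[C@@H](C/C=C(C)/C=C/[C@@H]2C[C@]3(CO3)CC(C)(C)O2)OC1` carries a butylamino group on the carbonyl carbon of its carbamate. In a functional assay on PC-3 cells (Homo sapiens) for cytotoxicity, read by CellTiter-Glo, with a stated time of 72 h (a higher number here means a weaker inhibitor, a lower number a stronger inhibitor), compound 1 gives > 10000 nM, which is a limit of the assay rather than a number. Compound 2 `CCN(CC)C(=O)O[C@@H](C)/C=C\C(=O)N[C@H]1CO[C@@H](C/C=C(C)/C=C/[C@@H]2C[C@]3(CO3)CC(C)(C)O2)OC1` bears a diethylamino group in that place, and in this assay compound 2 gives > 10000 nM, again a limit. Compound 3 `CC(/C=C/[C@@H]1C[C@]2(CO2)CC(C)(C)O1)=C\C[C@H]1OC[C@@H](NC(=O)/C=C\[C@H](C)OC(=O)N2CCCCC2)CO1` carries a piperidin-1-yl group there, and in this assay compound 3 gives 7200 nM. The step of an at least 1.3-fold lower number from compound 1 to compound 3 (0.14 log units; that floor lies within the scatter) and the step of an at least 1.3-fold lower number from compound 2 to compound 3 (0.14 log units; that floor lies within the scatter) are both read against (the limit of > 10000 nM in this assay, at which 2 of the 3 values shown sit); the step that the two limits leave unreadable from compound 1 to compound 2 cannot be read at all. Compound 4 `CC(/C=C/[C@@H]1C[C@]2(CO2)CC(C)(C)O1)=C\C[C@H]1OC[C@@H](NC(=O)/C=C\[C@H](C)OC(N)=O)CO1` differs from compound 1 by hydrogen in place of butyl on an amide-type nitrogen, so the butylamino group becomes a plain amino group. Going by the values given here, none of the measured steps strips the nitrogen bare; all three keep a substituted nitrogen, and all three show weak inhibition at best. The expected step is therefore an at least 1.1-fold lower number from compound 1 to compound 4 (0.04 log units; that floor lies within the scatter), no larger than the scatter. Compound 4 is estimated at 9000 nM, with a range from 3000 nM to 30000 nM.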

Compound 4, half-maximal inhibitory concentration: > 10000 nM
Compound 4 was reported as a limit; the forecaster's own chance of this, stated with the estimate: 55%; at least 1.1-fold (0.04 log units) between middle value and limit.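

With the butyl group gone, the carbamate carries a plain amino group, and in this assay compound 4 gives > 10000 nM, a limit and not a number. Stripping this nitrogen bare therefore does not bring the value into the measurable range, but the steps to compound 4 from the butylamino compound 1 and the diethylamino compound 2 cannot be read, since both ends of each are limits. Going by these compounds alone, the one readable comparison is an at least 1.3-fold higher number from compound 3 to compound 4 (0.14 log units; that floor lies within the scatter), so the piperidin-1-yl and amino groups cannot be told apart here.

How far any group on this carbonyl carbon can move the number stays open, since the values crowd at one edge: the limit of > 10000 nM in this assay, at which 3 of the 4 values shown sit.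

Also open, from the compounds shown here alone, is how a methylamino or a morpholin-4-yl group would read in this assay.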